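Swapping a Methylpyrrole Amide for a Furan Amide

A few compounds are considered here, and "the series" means these few. Any claim that something is new, unique, unknown or untested is made for them only; others in the source may bear on it.

Going by the values given here, compound 2 `Cn1cccc1C(=O)N[C@H]1CCc2nc(N)sc2C1` is the only compound in this small set with a measured number in an assay with sodium channel protein type 4 subunit alpha (Homo sapiens) as the target, read by patch clamp; a lower number here means a stronger inhibitor, a higher number a weaker inhibitor: there compound 2 gives 16000 nM. Compound 1 `Nc1nc2c(s1)C[C@@H](NC(=O)c1ccc[nH]1)CC2` differs from it only by a hydrogen in place of the methyl on the aromatic nitrogen. In this assay compound 1 reaches only a limit, > 30000 nM, (the limit of > 30000 nM in this assay, at which 1 of the 2 values shown sits). Among the compounds with values here, the single measured step, an at least 1.8-fold lower number from compound 1 to compound 2 (0.27 log units; that floor lies within the scatter), therefore rests on that limit and is itself no larger than the scatter.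

Compound 3 `Nc1nc2c(s1)C[C@@H](NC(=O)c1ccco1)CC2` carries furan-2-yl in place of 1-methyl-1H-pyrrol-2-yl on a carbonyl carbon. Within the data shown here, no measured step exchanges the aromatic ring itself; the only known step changed a hydrogen for a methyl on the nitrogen of that ring, so it offers no direct guide to this change. With nothing pointing either way, compound 3 is estimated at 20000 nM, between 6000 nM and 60000 nM. That estimate means an expected step of a 1.3-fold higher number from compound 2 to compound 3 (0.10 log units; within the scatter), within the scatter.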

Compound 3, half-maximal inhibitory concentration: > 30000 nM
Compound 3: no number, only a limit; the forecaster's own chance of this, stated with the estimate: 35%; at least 1.5-fold (0.17 log units) between middle value and limit.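

Furan-2-yl in place of 1-methyl-1H-pyrrol-2-yl on a carbonyl carbon gives, in this assay, an at least 1.8-fold higher number from compound 2 to compound 3 (0.27 log units; that floor lies within the scatter). This is the first step shown that exchanges the aromatic ring itself, but it fixes only a floor for the size of the change, and that floor stays within the scatter. Compound 3 gives a limit of the assay rather than a number, as compound 1 does: the limit of > 30000 nM in this assay, at which 2 of the 3 values shown sit.

As far as these compounds go, the step from compound 1 to compound 3 joins two limits and cannot be read, so any difference between furan-2-yl and 1H-pyrrol-2-yl at this place stays open. Also open, from the compounds shown here alone, is whether a different group on this carbonyl carbon, such as phenyl or cyclohexyl, would give a measured number in this assay.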